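Nitro Added to the Phenyl Ring of Compound 3

The source may report more compounds than this note shows. Statements on the series, on what has been measured and on what is new or still open speak of the compounds shown alone.

Three pyrazoline-bearing compounds have been measured so far in a functional assay on IMR-32 cells (Homo sapiens) for cytotoxicity, read by sulforhodamine B assay, with a stated time of 48 h; a lower number here means a stronger inhibitor, a higher number a weaker inhibitor. Compound 1 `CC(=O)N1N=C(c2ccccc2)CC1c1ccc(N(C)C)cc1` gives 9660 nM in this assay. Compound 2 `COc1ccc(OC)c(C2CC(c3cccc4ccccc34)=NN2C(C)=O)c1` gives 1580 nM, a lower number than either of the other two, and its distance from compound 3 lies beyond the scatter. Compound 3 `O=CCN1N=C(c2ccc3ccccc3c2)CC1c1ccccc1` gives 10000 nM, the highest of the three numbers shown; compound 1 sits within the scatter of it, so no order between these two can be read.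

The next compound, compound 4 `O=CCN1N=C(c2ccc3ccccc3c2)CC1c1cccc([N+](=O)[O-])c1`, differs from compound 3 in one place: nitro in place of hydrogen on an aromatic carbon. Cut one bond further out, the change reads phenyl to 3-nitrophenyl. Within the data shown here, no pair of measured compounds shows this change, so there is no step on record to lean on, and the only anchor is the value of compound 3 in this assay, 10000 nM.

With nothing to point strongly in either direction, compound 4 is expected to land close to compound 3, with at most a modest move toward a lower number, an expected step from compound 3 to compound 4 of a 1.4-fold lower number from compound 3 to compound 4 (0.15 log units; within the scatter) in this assay. The estimate for compound 4 is therefore 7000 nM, with a range from 2500 nM to 20000 nM.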

Compound 4, half-maximal inhibitory concentration: 3280 nM
The estimate for compound 4 lay 2.1-fold (0.33 log units) above the measured number, within the range that was stated.
By their numbers in this assay, from the lowest: compound 2; then compound 4; then compounds 1 and 3 (each within the scatter of the next).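

In this assay, nitro in place of hydrogen on this phenyl ring gives a 3.0-fold lower number from compound 3 to compound 4 (0.48 log units; beyond the scatter), and that step lies beyond the scatter. Among these compounds, it is the first change in one place on record in this set, so it shows something the earlier compounds could not: a group on this aromatic carbon, meta to a large group, can shift the number, and here it shifts it downward, while the rest of compound 4 stays as in compound 3. The result says where the number moved and by how much, but no measurement at hand speaks to why it moved.

As far as these compounds go, what stays open is whether the lower number belongs to nitro itself or would also follow from another group on the same carbon, such as a carboxylic acid, an amine or a single chlorine atom, and whether the same group on another carbon of this ring would give a step of similar size. From the compounds shown here alone, it also remains unknown whether the change from phenyl to 3-nitrophenyl would carry over to compounds built on a different core, such as that of compound 1 or compound 2.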